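The source may hold more compounds than are shown below. What is called first, only, known or untested is meant among the compounds shown, and "the series" means these compounds.

For the measured compounds named here, only two compounds sharing one core have been measured so far in a functional assay on HCT-116 cells (Homo sapiens) for inhibition, read by MTT assay, with a stated time of 48 h; a higher number here means a weaker inhibitor, a lower number a stronger inhibitor. Compound 1 `COc1cc(-c2cc(=O)[nH]c3c(O)c(OC)ccc23)cc([Se]C)c1OC`, which carries a selenium-containing group, gives 124 nM. Compound 2 `COc1cc(-c2cc(=O)[nH]c3c(O)c(OC)ccc23)cc(SC)c1OC`, which has sulfur in place of that selenium, gives 28.8 nM, the lower and therefore stronger of the two numbers.

The next compound is compound 3 `COc1cc(-c2c(C)c(=O)[nH]c3c(O)c(OC)ccc23)cc(SC)c1OC`, which differs from compound 2 by a single change: methyl in place of hydrogen on an aromatic carbon. In words, this is methyl in place of hydrogen on an aromatic carbon, ortho to a large group and two atoms from the ring nitrogen.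

Going by the values given here, the only measured step, a 4.3-fold lower number from compound 1 to compound 2 (0.63 log units; beyond the scatter), lies at another place on the molecule. It shows that one small swap can move the number modestly in this series, but it says nothing direct about the new methyl. Among the compounds with values here, no measured compound carries a methyl there, so even the direction is uncertain. Within the data shown here, with compound 2 at 28.8 nM, the lowest number so far, a modest rise seems likelier than a further drop. The expected change in this assay is a 2.1-fold higher number from compound 2 to compound 3 (0.32 log units; beyond the scatter). Compound 3 is estimated at 60 nM, with an expected range from 12 nM to 300 nM.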

Compound 3, half-maximal inhibitory concentration: 229 nM
Compound 3: the middle estimate sits 3.8-fold (0.58 log units) below what was measured; measured number inside the range.
By their numbers in this assay, from the lowest: compound 2; then compounds 1 and 3 (each within the scatter of the next).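

In this assay, the new methyl, ortho to a large group and two atoms from the ring nitrogen, gives a clear loss of inhibition (an 8.0-fold higher number from compound 2 to compound 3 (0.90 log units; beyond the scatter)). For the compounds shown here, until now, the only measured change lay elsewhere on the molecule, so this is the first sign that this position also responds to substitution, and that even a group of a single heavy atom is enough to shift the number beyond the scatter. Compound 2, with hydrogen at this place, remains the strongest inhibitor of the three, and nothing available explains why the methyl raises the number.

As far as these compounds go, with only hydrogen and methyl compared here, it remains open whether any group at this carbon would raise the number or whether the result is particular to methyl; a fluorine atom, a hydroxyl group, an amine or a longer chain such as ethyl could help to separate these possibilities. From the compounds shown here alone, it is also open whether methyl at this position would have a similar effect with the selenium-containing group of compound 1 in place of the sulfur-containing group.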